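The source may hold more compounds than are shown below. What is called first, only, known or untested is meant among the compounds shown, and "the series" means these compounds.

Measured so far:
Compound 1, `Cc1cc(=O)[nH]c(=O)n1COC(CO)CO`, gives in a functional assay on MIA PaCa-2 cells (Homo sapiens) for inhibition, read by MTT assay, with a stated time of 72 h (on this read-out lower numbers stand for stronger inhibition and higher numbers for weaker inhibition), a reading of > 100000 nM, which is a limit of the assay and not a number.
Compound 2, `O=c1ccn(COC(CO)CO)c(=O)[nH]1`, gives in this assay a reading of > 100000 nM, which is again a limit of the assay.

Compound 2 therefore stands only at a limit in this assay; no actual number is known for it. Going by the values given here, the single measured step, a step that the two limits leave unreadable from compound 1 to compound 2, cannot be read in size: the limit of > 100000 nM in this assay, at which 2 of the 2 values shown sit, is where both of its ends sit. Compound 3, `Nc1cn(COC(CO)CO)c(=O)[nH]c1=O`, differs from compound 2 by amino in place of hydrogen on an aromatic carbon. Among the compounds with values here, no measured step bears directly on this change; the only known step concerns a different group and is itself unreadable. Within the data shown here, the numbers so far show no measured effect of a small change on an aromatic carbon of this shared core. The expected step that the limit leaves unreadable from compound 2 to compound 3 is thus none beyond the scatter. Compound 3 is therefore expected to give 150000 nM in this assay, with a range from 50000 nM to 500000 nM, and most likely it will again be reported only as a limit.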

Compound 3, half-maximal inhibitory concentration: > 100000 nM
Compound 3 was reported as a limit; the forecaster's own chance of this, stated with the estimate: 85%; the middle value is on the limit's open side.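

Compound 3, like compound 2, gives only a limit and not a number, so the step between them cannot be read in size, and the same holds for compound 1 and compound 2: the limit of > 100000 nM in this assay, at which 3 of the 3 values shown sit.

Left open is what actual number any of these compounds would give in this assay and whether methyl or amino on an aromatic carbon of the shared core changes that number at all.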